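The compounds below may be only part of what the source reports. "The series", "measured", "known", "first", "only" and "open" are said of these compounds alone.

Measured compounds:
compound 1, `COC(=O)c1sc2cc(C#Cc3ccc(N)cc3)cnc2c1N`, 4800 nM
compound 2, `COC(=O)c1sc2cc(C#Cc3ccc(F)cc3)cnc2c1N`, 48400 nM
compound 3, `COC(=O)c1sc2cc(C#Cc3ccccc3F)cnc2c1N`, a limit of > 150000 nM

Of the compounds shown here, three sharing one core have been tested in a functional assay on A375-C5 cells (Homo sapiens) for inhibition, read by sulforhodamine B assay, with a stated time of 48 h; on this read-out lower numbers stand for stronger inhibition of growth and higher numbers for weaker inhibition of growth. Compound 1 gives 4800 nM, the lowest of the two numbers obtained. Compound 2 gives 48400 nM, and the step of a 10-fold higher number from compound 1 to compound 2 (1.00 log units; beyond the scatter). For compound 3 this assay reports only a limit, > 150000 nM, as stated by the limit of > 150000 nM in this assay, at which 1 of the 3 values shown sits. The step of an at least 3.0-fold higher number from compound 2 to compound 3 (0.49 log units; beyond the scatter), and the step of an at least 31-fold higher number from compound 1 to compound 3 (1.49 log units; beyond the scatter).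

Compound 4, `COC(=O)c1sc2cc(C#Cc3ccccc3N)cnc2c1N`, has not yet been measured in this assay. It differs from compound 1 in one place: 2-aminophenyl in place of 4-aminophenyl on a triple-bonded carbon. Going by the values given here, the measured step that bears most directly on this change is the one from compound 2 to compound 3, where the same move of a substituent on the phenyl ring gave an at least 3.0-fold higher number from compound 2 to compound 3 (0.49 log units; beyond the scatter). On that basis a higher number for compound 4 than for compound 1 is expected, of a size beyond the scatter, though the amino group may not follow the fluoro exactly. Compound 4 is therefore estimated at 20000 nM, with a range from 5000 nM to 80000 nM, which means an expected step of a 4.2-fold higher number from compound 1 to compound 4 (0.62 log units; beyond the scatter).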

Compound 4, concentration for 50% growth inhibition: 3100 nM
Estimate against measurement, compound 4: 6.5-fold (0.81 log units) above; the whole stated range lies above it.
By their numbers in this assay, from the lowest: compounds 4 and 1 (each within the scatter of the next); then compound 2. At a limit, above all of these: compound 3.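

In this assay, moving the amino group from 4-aminophenyl to 2-aminophenyl leaves the number within the scatter, with a 1.5-fold lower number from compound 1 to compound 4 (0.19 log units; within the scatter), so the change that went with weaker inhibition of growth in the fluoro pair has no readable effect in the amino pair. Compound 4 also stands clear of both fluoro compounds, with a 16-fold lower number from compound 2 to compound 4 (1.19 log units; beyond the scatter) and an at least 48-fold lower number from compound 3 to compound 4 (1.68 log units; beyond the scatter), the latter step resting on a limit for compound 3. Amino and fluoro can now be compared on both placements, and the change does not have a single size, as the two steps differ by more than the scatter allows: the same change on two cores in this assay, a 10-fold higher number (1.00 log units; beyond the scatter) from compound 1 to compound 2 and an at least 48-fold higher number (1.68 log units; beyond the scatter) from compound 4 to compound 3, at least 4.7-fold (0.68 log units) apart, beyond the scatter of two such steps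

The compounds shown leave open whether a dimethylamino group or an acetamide in place of the amino group would keep numbers at the level of compound 1 and compound 4. They also leave open whether a hydroxyl group would follow the amino compounds or the fluoro compounds, and the four numbers alone do not say why the amino group reads as it does.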